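A Nitro-to-Methoxy Change Repeated on a Second Core

This account rests on a few compounds, and the source may have more. Where it says the series, first, only, none or still open, it means among the compounds named here.

Measured compounds:
Compound 1, `CCOC(=O)c1cc(-c2ccccc2)nn1CC(O)COc1ccccc1[N+](=O)[O-]`: 30000 nM
Compound 2, `CCOC(=O)c1cc(-c2ccccc2)nn1CC(O)COc1ccccc1OC`: 58000 nM
Compound 3, `CCOC(=O)c1cc(-c2ccc(Cl)cc2)nn1CC(O)COc1ccccc1[N+](=O)[O-]`: 26000 nM

All three were tested in a functional assay on A549 cells (Homo sapiens) for inhibition, read by MTT assay, with a stated time of 48 h; a higher number here means a weaker inhibitor, a lower number a stronger inhibitor. Compound 2 differs from compound 1 by methoxy in place of nitro on an aromatic carbon, and this gave a 1.9-fold higher number from compound 1 to compound 2 (0.29 log units; within the scatter). Compound 3 differs from compound 1 by chloro in place of hydrogen on an aromatic carbon, with a 1.2-fold lower number from compound 1 to compound 3 (0.06 log units; within the scatter). Compound 3 has the lowest number of the three, but against compound 1 this lies within the scatter, so no order between compound 3 and compound 1 is claimed.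

Compound 4, `CCOC(=O)c1cc(-c2ccc(Cl)cc2)nn1CC(O)COc1ccccc1OC`, has not yet been measured in this assay. It differs from compound 3 by methoxy in place of nitro on an aromatic carbon. This is the same change as the one from compound 1 to compound 2, placed on a core that differs by the chloro described above. Going by the values given here, because the earlier step was a 1.9-fold higher number from compound 1 to compound 2 (0.29 log units; within the scatter), a step of about the same size is expected here, a 1.9-fold higher number from compound 3 to compound 4 (0.28 log units; within the scatter), resting on the single earlier example only. Compound 4 is therefore estimated at 50000 nM, with a range from 25000 nM to 100000 nM.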

Compound 4, half-maximal inhibitory concentration: 32000 nM
The estimate for compound 4 lay 1.6-fold (0.19 log units) above the measured number; measured number inside the range.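

In this assay, methoxy in place of nitro on the chloro-bearing core gave a 1.2-fold higher number from compound 3 to compound 4 (0.09 log units; within the scatter), and chloro in place of hydrogen on the methoxy-bearing core gave a 1.8-fold lower number from compound 2 to compound 4 (0.26 log units; within the scatter). Across the two cores, the change from nitro to methoxy shows no difference that can be told from the scatter: the same change on two cores in this assay, a 1.9-fold higher number (0.29 log units; within the scatter) from compound 1 to compound 2 and a 1.2-fold higher number (0.09 log units; within the scatter) from compound 3 to compound 4, 1.6-fold (0.20 log units) apart, within the scatter of two such steps All of these steps are small enough to lie within the scatter, so the agreement shows only that no dependence on the core can be seen, not that either change has a real, fixed effect that carries from one core to another, and chloro in place of hydrogen reads the same way: the same change on two cores in this assay, a 1.2-fold lower number (0.06 log units; within the scatter) from compound 1 to compound 3 and a 1.8-fold lower number (0.26 log units; within the scatter) from compound 2 to compound 4, 1.6-fold (0.20 log units) apart, within the scatter of two such steps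

The compounds shown leave open how an amine or a carboxylic acid in place of the nitro or methoxy would behave on these cores. They also leave open whether the pattern would hold with a fluoro or a methyl in place of the chloro, or with a carboxylic acid in place of the ethyl ester.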